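A Methyl Added to a Saturated Ring of Compound 1

This account rests on a few compounds, and the source may have more. Where it says the series, first, only, none or still open, it means among the compounds named here.

Measured compounds:
compound 1 `O=C1CCCCC1C1CC(=O)N(Cc2ccccc2)C1=O` — 36000 nM
compound 2 `NS(=O)(=O)c1ccc(N2C(=O)CC(C3CCCCCC3=O)C2=O)cc1` — 16200 nM
compound 3 `O=C1CCCCC1C1CC(=O)N(c2ccc(Br)cc2)C1=O` — 131000 nM

Of the compounds shown here, three sharing the core of compound 1 have been tested in an assay on cells (1-87 tumor cell line) for inhibition of Polyunsaturated fatty acid 5-lipoxygenase (Homo sapiens), with a stated time of 5 min; on this read-out lower numbers stand for stronger inhibition and higher numbers for weaker inhibition. Compound 1 gives 36000 nM, the second highest of the three numbers. Its nearest neighbour is compound 2, which in this assay gives 16200 nM, a gap that lies beyond the scatter. Furthest away is compound 3, which gives 131000 nM, also beyond the scatter. For the measured compounds named here, only one pair of measured compounds differs in a single place: a 3.6-fold higher number from compound 1 to compound 3 (0.56 log units; beyond the scatter).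

The next compound is compound 4 `CC1CCC(=O)C(C2CC(=O)N(Cc3ccccc3)C2=O)C1`. It differs from compound 1 in one place: methyl in place of hydrogen on a saturated ring carbon. Going by the values given here, the one measured step concerns the group on the amide-type nitrogen in a ring and says nothing about a change on the six-membered non-aromatic ring of carbon only. Among the compounds with values here, no measured step therefore bears directly on this change, and a methyl in place of hydrogen is a small addition. The expectation in this assay is a step of no more than the scatter, with no clear direction.

Compound 4 is therefore estimated at 36000 nM, within a range from 15000 nM to 90000 nM. This estimate means an expected step of no change at the digits printed from compound 1 to compound 4 (within the scatter).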

Compound 4, half-maximal inhibitory concentration: 56200 nM
Compound 4: the middle estimate sits 1.6-fold (0.19 log units) below what was measured, within the range that was stated.
By their numbers in this assay, from the lowest: compound 2; then compounds 1 and 4 (each within the scatter of the next); then compound 3.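

In this assay, methyl in place of hydrogen on a saturated ring carbon, two ring bonds from the ring atom that bears a large group, gives a 1.6-fold higher number from compound 1 to compound 4 (0.19 log units; within the scatter). For the compounds shown here, this is the first measured step on the six-membered non-aromatic ring of carbon only, and it shows that this position takes the added methyl with no change that can be told from the scatter, whereas the one earlier step, on the amide-type nitrogen in a ring, gave a 3.6-fold higher number from compound 1 to compound 3 (0.56 log units; beyond the scatter). No evidence is at hand that accounts for this result.

The compounds shown leave open whether a larger or different group on the same ring carbon, such as ethyl, a longer chain, a hydroxyl or an amine, would also stay within the scatter. They also leave open whether methyl would give the same small step on another carbon of this ring, or with the 4-bromophenyl of compound 3 in place of the benzyl on the amide-type nitrogen.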